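Carbamate in place of isobutyramide on a pyrazole amine

A few compounds are considered here, and "the series" means these few. Any claim that something is new, unique, unknown or untested is made for them only; others in the source may bear on it.

Compound 2 `Cc1cc(NC(=O)C(C)C)nn1Cc1cc(Cl)ccc1OCc1ccccc1` gives 25.1 nM in an assay on CHO-K1 cells for displacement of a labelled ligand from prostaglandin E2 receptor EP1 subtype (Homo sapiens) (on this read-out higher numbers stand for weaker inhibition and lower numbers for stronger inhibition), the lowest of the two numbers seen. Compound 1 `Cc1cc(C(=O)NCc2ccncc2)nn1Cc1cc(Cl)ccc1OCc1ccccc1` gives 79.4 nM, and the step of a 3.2-fold lower number from compound 1 to compound 2 (0.50 log units; beyond the scatter) changed a side group on the shared core. Compound 3 `Cc1cc(NC(=O)OCc2ccccc2)nn1Cc1cc(Cl)ccc1OCc1ccccc1` differs from compound 2 by benzyloxy in place of isopropyl on a carbonyl carbon. Among the compounds with values here, no measured step alters this carbonyl substituent, so the earlier step offers only a loose guide to how much the number may move. With a larger group entering, a modest shift is expected, in either direction, as a 1.3-fold higher number from compound 2 to compound 3 (0.11 log units; within the scatter). Compound 3 is therefore estimated at 32 nM, within 8 nM to 130 nM.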

Compound 3, half-maximal inhibitory concentration: 79.4 nM
For compound 3 the middle estimate is 2.5-fold (0.39 log units) below the measured one; low and high end bracket the measured number.
By their numbers in this assay, from the lowest: compound 2; then compounds 1 and 3 (each within the scatter of the next).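

In this assay the carbonyl carbon proves sensitive to what it carries: benzyloxy in place of isopropyl gives a 3.2-fold higher number from compound 2 to compound 3 (0.50 log units; beyond the scatter) and so weaker inhibition. Two quite different groups on an aromatic carbon, (benzyloxycarbonyl)amino and ((pyridin-4-yl)methyl)carbamoyl, read alike, with no change at the digits printed from compound 1 to compound 3 (within the scatter) on this read-out. Nothing available here explains the step.

The compounds shown leave open whether the added oxygen or the aromatic ring accounts for the step. Methoxy or 2-phenylethyl on that carbonyl carbon would separate the two.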